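Phenyl in place of isopropyl: working notes

This account rests on a few compounds, and the source may have more. Where it says the series, first, only, none or still open, it means among the compounds named here.

In a functional assay on PC-12 cells (Rattus norvegicus) for inhibition, read by sulforhodamine B assay (on this read-out lower numbers stand for stronger inhibition and higher numbers for weaker inhibition), compound 1 (`O=C1NC(=O)C(Cc2ccc(OCC3CCCCC3)cc2)S1`) gives 26000 nM and compound 2 (`CC(C)COc1ccc(CC2SC(=O)NC2=O)cc1`) gives 25000 nM. Compound 2 therefore stands level with compound 1 within the scatter, and the two measured compounds set a single working level for the series.

Next is compound 3 (`O=C1NC(=O)C(Cc2ccc(OCc3ccccc3)cc2)S1`), reached from compound 2 by this change: phenyl in place of isopropyl on a saturated chain carbon bound to an oxygen on an aromatic ring. In words, phenyl takes the place of isopropyl on a saturated chain carbon bound to an oxygen on an aromatic ring.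

Going by the values given here, only one measured step bears on this place: a 1.0-fold lower number from compound 1 to compound 2 (0.02 log units; within the scatter). That exchange of cyclohexyl and isopropyl left the number within the scatter. Among the compounds with values here, no measured compound carries phenyl at this place, so the support is indirect and the range should stay wide. On this evidence, no step beyond the scatter is expected in this assay. The expected step is no change at the digits printed from compound 2 to compound 3 (within the scatter). The estimated value for compound 3 is 25000 nM, with an expected range from 12000 nM to 50000 nM.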

Compound 3, half-maximal inhibitory concentration: > 100000 nM
Compound 3 was reported as a limit (the forecaster's own chance of this, stated with the estimate: 10%); middle value at least 4.0-fold (0.60 log units) from the limit.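

The place on a saturated chain carbon bound to an oxygen on an aromatic ring is not indifferent to the group it carries in this assay: cyclohexyl and isopropyl stood level within the scatter, yet phenyl brings an at least 4.0-fold higher number from compound 2 to compound 3 (0.60 log units; beyond the scatter) and an at least 3.8-fold higher number from compound 1 to compound 3 (0.58 log units; beyond the scatter). Carrying a ring at this place is not what separates the compounds, since the saturated ring of compound 1 stays level with the open isopropyl of compound 2, while the six-membered aromatic ring of carbon only in compound 3 does not. Compound 3 stands as a limit and not as a number, so both steps give a direction and a minimum size only: the limit of > 100000 nM in this assay, at which 1 of the 3 values shown sits.

The compounds shown leave open whether the weaker result belongs to the aromatic ring as such or would persist with a pyridyl group or a methoxy-bearing phenyl at the same place. They also leave open whether any group here moves the number below the level shared by compound 1 and compound 2, for instance a longer chain ending in an amine or a carboxylic acid.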